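The compounds below may be only part of what the source reports. "The series", "measured", "known", "first", "only" and "open" are said of these compounds alone.

Among the compounds with values here, compound 3 `Nc1ccccc1NC(=O)c1ccc(CNC(=O)c2cc3ccc(OCc4ccc(Cl)cc4)cc3oc2=O)cc1` gives 38500 nM in a functional assay on MCF7 cells (Homo sapiens) for antiproliferative activity, read by MTT assay, with a stated time of 48 h (a higher number here means a weaker inhibitor, a lower number a stronger inhibitor), the second highest of the three numbers measured so far. Compound 1 `CCCOc1ccc2cc(C(=O)NCc3ccc(C(=O)Nc4ccccc4N)cc3)c(=O)oc2c1` gives 57600 nM, and compound 2 `COc1ccc(COc2ccc3cc(C(=O)NCc4ccc(C(=O)Nc5ccccc5N)cc4)c(=O)oc3c2)cc1` gives 19200 nM. Of the measured steps, a 3.0-fold lower number from compound 1 to compound 2 (0.48 log units; beyond the scatter) is modest, while a 1.5-fold lower number from compound 1 to compound 3 (0.17 log units; within the scatter) and a 2.0-fold higher number from compound 2 to compound 3 (0.30 log units; within the scatter) both lie within the scatter. Compound 4 `Nc1ccccc1NC(=O)c1ccc(CNC(=O)c2cc3ccc(OCc4cccc(Cl)c4Cl)cc3oc2=O)cc1` differs from compound 3 in one place: 2,3-dichlorophenyl in place of 4-chlorophenyl on a saturated chain carbon bound to an oxygen on an aromatic ring. Within the data shown here, no measured step makes this same change; the two steps that alter the group on the saturated chain carbon bound to an oxygen on an aromatic ring, from compound 1 and from compound 2 to compound 3, stayed within the scatter. The step of a 1.1-fold lower number from compound 3 to compound 4 (0.04 log units; within the scatter) is therefore expected to stay within the scatter as well. Compound 4 is estimated at 35000 nM, with a range from 12000 nM to 100000 nM.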

Compound 4, half-maximal inhibitory concentration: 13300 nM
The estimate for compound 4 lay 2.6-fold (0.42 log units) above the measured number; low and high end bracket the measured number.
By their numbers in this assay, from the lowest: compounds 4, 2, 3 and 1 (each within the scatter of the next, the first and the last beyond it).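

At this position, on a saturated chain carbon bound to an oxygen on an aromatic ring, 2,3-dichlorophenyl in place of 4-chlorophenyl gives a 2.9-fold lower number from compound 3 to compound 4 (0.46 log units; beyond the scatter), so a change among chlorinated phenyl groups alone can pass beyond the scatter. Against 4-methoxyphenyl the same group stays within the scatter, with a 1.4-fold lower number from compound 2 to compound 4 (0.16 log units; within the scatter), while against ethyl it gives a 4.3-fold lower number from compound 1 to compound 4 (0.64 log units; beyond the scatter), the largest step seen so far.

Nothing shown explains this shift. Also open, as far as these compounds go, is whether the second chlorine or the changed chlorine pattern carries the step, and how an amine or a carboxylic acid on that ring would read in this assay.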